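The compounds below may be only part of what the source reports. "The series", "measured", "known", "first", "only" and "open" are said of these compounds alone.

Of the compounds shown here, three with a shared core have been tested in a functional assay on NPC-TW01 cells (Homo sapiens) for inhibition, read by MTT assay, with a stated time of 72 h; a higher number here means a weaker inhibitor of growth, a lower number a stronger inhibitor of growth. Compound 1 `COC(=O)c1nc(C)n(-c2ccc(F)cc2)n1` gives 15200 nM in this assay. Compound 2 `COC(=O)c1nc(C(C)C)n(-c2ccc(F)cc2)n1` reaches only the limit of the assay, > 100000 nM, which is not a number but the point at which the measurement stops (the limit of > 100000 nM in this assay, at which 1 of the 3 values shown sits). Compound 3 `COC(=O)c1nc(-c2ccc[nH]2)n(-c2ccc(F)cc2)n1` gives 9580 nM, the lowest of the two numbers available; its nearest neighbour is compound 1, and the two sit within the usual scatter of each other a 1.6-fold lower number from compound 1 to compound 3 (0.20 log units; within the scatter). Against compound 2 the step is much larger an at least 10-fold lower number from compound 2 to compound 3 (1.01 log units; beyond the scatter).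

Compound 4 `COC(=O)c1nc(-c2ccccc2)n(-c2ccc(F)cc2)n1` has not yet been measured. It differs from compound 3 in one place: phenyl in place of 1H-pyrrol-2-yl on an aromatic carbon. Two measured steps change the group at this same aromatic carbon. The change from methyl to the five-membered ring stayed within the scatter, while the change from isopropyl to that ring was large; swapping one aromatic ring for another seems a smaller move than either. No step beyond the scatter is therefore expected from compound 3 to compound 4 in this assay a 1.1-fold lower number from compound 3 to compound 4 (0.03 log units; within the scatter). Compound 4 is estimated at 9000 nM, with a range from 3000 nM to 30000 nM.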

Compound 4, concentration for 50% growth inhibition: 15600 nM
The estimate for compound 4 lay 1.7-fold (0.24 log units) below the measured number; the measured number falls inside the stated range.
By their numbers in this assay, from the lowest: compounds 3, 1 and 4 (each within the scatter of the next). At a limit, above all of these: compound 2.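

Swapping the five-membered ring for phenyl removes the ring's hydrogen-bond donor, yet in this assay the result cannot be told from scatter (a 1.6-fold higher number from compound 3 to compound 4 (0.21 log units; within the scatter)), and phenyl cannot be told from methyl either (a 1.0-fold higher number from compound 1 to compound 4 (0.01 log units; within the scatter)). At this aromatic carbon, then, a donor on the group is not required for compound 4 to match compound 3, and a larger aromatic ring reads like methyl. Isopropyl alone stands apart among the groups shown (an at least 6.4-fold lower number from compound 2 to compound 4 (0.80 log units; beyond the scatter)), and the value for compound 2 is a limit, not a number: the limit of > 100000 nM in this assay, at which 1 of the 4 values shown sits.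

On these data alone, whether an amine, a carboxylic acid or a longer chain at this carbon would side with isopropyl or with the other groups remains open. So does what separates isopropyl from methyl and phenyl.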